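A few compounds are considered here, and "the series" means these few. Any claim that something is new, unique, unknown or untested is made for them only; others in the source may bear on it.

Compound 1 `CC(C)(C)Cc1cnc(CCc2ccc(-c3ccccc3C(=O)O)cc2)[nH]1` gives 6.3 nM in an in vitro functional assay on cells for agonist activity at Bombesin receptor subtype-3 (Mus musculus), read by luminescence and calcium flux; a lower number here means that less compound is needed, a higher number that more compound is needed for the effect. Compound 2 `CCCCc1cnc(CCc2ccc(-c3ccccc3C(=O)O)cc2)[nH]1` gives 93 nM.

Compound 2 stands highest of the two numbers; its nearest neighbour is compound 1, reached by the step of a 15-fold higher number from compound 1 to compound 2 (1.17 log units; beyond the scatter). Compound 3 `COc1ccccc1Cc1cnc(CCc2ccc(-c3ccccc3C(=O)O)cc2)[nH]1` differs from compound 2 by 2-methoxyphenyl in place of propyl on a saturated chain carbon bound to an aromatic carbon. Within the data shown here, the only step that bears on this place is a 15-fold higher number from compound 1 to compound 2 (1.17 log units; beyond the scatter), which shows that the group on this saturated chain carbon shifts the number widely. No aromatic group has been tested at this place, so the direction rests on that single step alone. Compound 3 is expected to move by a 4.7-fold lower number from compound 2 to compound 3 (0.67 log units; beyond the scatter), toward a lower number. Compound 3 is therefore estimated at 20 nM, within 4 nM to 100 nM.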

Compound 3, half-maximal effective concentration: 163 nM
The estimate for compound 3 lay 8.2-fold (0.91 log units) below the measured number; measured number above the stated range.
By their numbers in this assay, from the lowest: compound 1; then compounds 2 and 3 (each within the scatter of the next).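

In this assay, replacing propyl with 2-methoxyphenyl at this saturated chain carbon, with its added six-membered aromatic ring, gives a 1.8-fold higher number from compound 2 to compound 3 (0.24 log units; within the scatter) and so does not separate the two groups. Compound 1 remains apart, with a 26-fold higher number from compound 1 to compound 3 (1.41 log units; beyond the scatter) as the step, so among these three compounds only tert-butyl stands out at this place. The compounds shown leave open whether an unsubstituted phenyl or a cyclohexyl group here would fall with compound 2 and compound 3 or with compound 1. No measured evidence bears on why these groups fall as they do.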